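Compound 4 weighed against its three measured neighbours

The source may hold more compounds than are shown below. What is called first, only, known or untested is meant among the compounds shown, and "the series" means these compounds.

Of the compounds shown here, three built on one shared core have been tested in a functional assay on HeLa cells (Homo sapiens) for cytotoxicity, read by MTT assay, with a stated time of 48 h; a lower number here means a stronger inhibitor, a higher number a weaker inhibitor. Compound 1 `Cc1cccc(Cn2cc(COc3ccc4c(=O)ccoc4c3)nn2)c1` gives only a limit there, > 100000 nM. Compound 2 `O=c1ccoc2cc(OCc3cn(Cc4ccc(Cl)cc4)nn3)ccc12` gives 37600 nM in this assay. Compound 3 `O=c1ccoc2cc(OCc3cn(Cc4cccc(Br)c4)nn3)ccc12` likewise gives only a limit, > 100000 nM. Compound 3 thus sits at the limit of this assay, the place where 2 of the 3 values shown rest (the limit of > 100000 nM in this assay, at which 2 of the 3 values shown sit).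

Compound 4 `O=c1ccoc2cc(OCc3cn(Cc4ccc([N+](=O)[O-])cc4)nn3)ccc12` differs from compound 3 in a single place: 4-nitrophenyl in place of 3-bromophenyl on a saturated chain carbon bound to an aromatic nitrogen. Two measured steps change the group on that same saturated chain carbon bound to an aromatic nitrogen: an at least 2.6-fold lower number from compound 1 to compound 2 (0.42 log units; beyond the scatter), and an at least 2.6-fold higher number from compound 2 to compound 3 (0.42 log units; beyond the scatter). The remaining step, a step that the two limits leave unreadable from compound 1 to compound 3, cannot be read because both ends are limits. Only compound 2, carrying 4-chlorophenyl, has produced a number; compound 4 carries 4-nitrophenyl. The step of an at least 1.6-fold lower number from compound 3 to compound 4 (0.22 log units; that floor lies within the scatter) is therefore expected to be small or modest, pulling the number down from the limit toward that of compound 2, though compound 4 may again give only a limit. For compound 4 the estimate in this assay is 60000 nM, within a range of 20000 nM to 150000 nM.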

Compound 4, half-maximal inhibitory concentration: 25700 nM
Estimate against measurement, compound 4: 2.3-fold (0.37 log units) above; the measured number falls inside the stated range.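

In this assay, compound 4 is the second compound on the shared core to give a number rather than a limit, and 4-nitrophenyl on the saturated chain carbon bound to an aromatic nitrogen gives two steps beyond the scatter: an at least 3.8-fold lower number from compound 3 to compound 4 (0.59 log units; beyond the scatter) and an at least 3.8-fold lower number from compound 1 to compound 4 (0.59 log units; beyond the scatter). With nitro in place of chloro on an aromatic carbon, compound 2 and compound 4 cannot be told apart, the step being a 1.5-fold lower number from compound 2 to compound 4 (0.17 log units; within the scatter). Across these four compounds, 4-chlorophenyl and 4-nitrophenyl give numbers, while compound 1 with 3-methylphenyl and compound 3 with 3-bromophenyl rest at a limit: the limit of > 100000 nM in this assay, at which 2 of the 4 values shown sit.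

Whether this split follows the identity of the group or its place on the phenyl ring cannot be read from these compounds. Going by these compounds, what an amine or a carboxylic acid in place of the nitro would give also remains open.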